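This account rests on a few compounds, and the source may have more. Where it says the series, first, only, none or still open, it means among the compounds named here.

In a functional assay on MGC-803 cells (Homo sapiens) for cytotoxicity, read by MTT assay, with a stated time of 72 h (on this read-out lower numbers stand for stronger inhibition and higher numbers for weaker inhibition), compound 1 (`CC(C)=C1C(=O)N(c2ccc(Cl)cc2)N(c2ccc(Cl)cc2)C1=O`) gives 39000 nM. Compound 2 (`O=C1C(=Cc2ccc(Cl)cc2)C(=O)N(c2ccc(Cl)cc2)N1c1ccc(Cl)cc1`) gives 32600 nM, within the scatter of compound 1, while compound 3 (`COc1cc(C=C2C(=O)N(c3ccc(Cl)cc3)N(c3ccc(Cl)cc3)C2=O)cc(OC)c1OC`) gives 17300 nM, a lower number beyond the scatter of compound 1. Compound 4 (`CC(=C1C(=O)N(c2ccc(Cl)cc2)N(c2ccc(Cl)cc2)C1=O)c1ccc(O)cc1`) differs from compound 1 in one place: 4-hydroxyphenyl in place of methyl on a double-bonded chain carbon bound to a double-bonded ring carbon and a saturated chain carbon. Like compound 4, compound 3 carries an oxygen-bearing aromatic ring, and it reads 17300 nM. A modest move towards lower numbers is therefore expected in this assay. The estimated change is a 2.2-fold lower number from compound 1 to compound 4 (0.34 log units; beyond the scatter). For compound 4 the estimated value is 18000 nM, with an expected range of 6000 nM to 45000 nM.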

Compound 4, half-maximal inhibitory concentration: 42800 nM
For compound 4 the middle estimate is 2.4-fold (0.38 log units) below the measured one, within the range that was stated.
By their numbers in this assay, from the lowest: compounds 3, 2, 1 and 4 (each within the scatter of the next, the first and the last beyond it).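

Within the data shown here, this is the first step in the set that changes one place only. In this assay, the step of a 1.1-fold higher number from compound 1 to compound 4 (0.04 log units; within the scatter) lies within the scatter, so replacing methyl with 4-hydroxyphenyl on this double-bonded chain carbon, which adds an aromatic ring and a hydrogen-bond donor, leaves the read-out unchanged. Nothing available explains this result.

The compounds shown leave open whether a single change at this carbon can move the number at all. An amine, a carboxylic acid or a longer chain in place of methyl might still read differently.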